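This account rests on a few compounds, and the source may have more. Where it says the series, first, only, none or still open, it means among the compounds named here.

Compound 1 `N=C1S/C(=C\c2ccc(OCc3ccccc3)cc2)C(=O)N1c1ncccn1` gives 26.6% in an ADME assay on RAW264.7 cells (Mus musculus) for cytotoxicity, read by MTT assay, with a stated time of 48 h, tested at 50 uM; a higher number here means more inhibition at the concentration tested (going by the name of the read-out), a lower number less inhibition.
Compound 2 `Cc1cccc(N2C(=N)S/C(=C\c3ccc(OCc4ccccc4)cc3)C2=O)n1` gives 25.1% in this assay.

Compound 2 stands with compound 1 within the scatter, since the step of a number 1.5 percentage points lower from compound 1 to compound 2 (within the scatter) is within the scatter. Compound 3 `N=C1S/C(=C\c2ccc(OCc3ccccc3)cc2)C(=O)N1c1ccccc1` differs from compound 2 in one place: phenyl in place of 6-methylpyridin-2-yl on an amide-type nitrogen in a ring. Within the data shown here, the only measured step that bears on this, the step of a number 1.5 percentage points lower from compound 1 to compound 2 (within the scatter), also exchanged the ring on the amide-type nitrogen and stayed within the scatter, so no step beyond the scatter is expected in this assay. Compound 3 is therefore estimated at 25%, in the range 14% to 36%, an expected step of a number 0.1 percentage points lower from compound 2 to compound 3 (within the scatter).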

Compound 3, a percentage reported as inhibition, at one concentration (the size of the read-out at that concentration, not a potency): 37.9%
Estimate against measurement, compound 3: 12.9 percentage points below; measured number above the stated range.
By their numbers in this assay, from the lowest: compounds 2 and 1 (each within the scatter of the next); then compound 3.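

In this assay the ring on the amide-type nitrogen now proves able to shift the number: phenyl, a ring of carbon only, gives a number 12.8 percentage points higher from compound 2 to compound 3 (beyond the scatter) and a number 11.3 percentage points higher from compound 1 to compound 3 (beyond the scatter) while the exchange between the two nitrogen-bearing rings stayed within the scatter. Nothing measured here accounts for this difference. The compounds shown leave open whether the ring nitrogen alone separates these results, as a 3-methylphenyl group would test, and whether a saturated ring such as piperidine at this place would behave like phenyl.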